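This account rests on a few compounds, and the source may have more. Where it says the series, first, only, none or still open, it means among the compounds named here.

Measured so far in a functional assay on PC-3 cells (Homo sapiens) for antiproliferative activity, read by WST assay, with a stated time of 3 days; a higher number here means a weaker inhibitor, a lower number a stronger inhibitor:
compound 1 `CCCCCOc1c(-c2cc(OC)c(OC)c(OC)c2)oc2ccccc2c1=O` gives 22200 nM
compound 2 `CCCCCCOc1c(-c2cc(OC)c(OC)c(OC)c2)oc2ccccc2c1=O` gives 29200 nM
compound 3 `CCN(CC)CCCCOc1c(-c2cc(OC)c(OC)c(OC)c2)oc2ccccc2c1=O` gives 13700 nM

The diethylamino member stands level with one neighbour and modestly clear of the other: the gap a 1.6-fold lower number from compound 1 to compound 3 (0.21 log units; within the scatter) is no separation, and the gap a 2.1-fold lower number from compound 2 to compound 3 (0.33 log units; beyond the scatter) is a small one.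

Still unmeasured is compound 4 `CCCCN(CCCC)CCCCOc1c(-c2cc(OC)c(OC)c(OC)c2)oc2ccccc2c1=O` with dibutylamino in place of diethylamino on a saturated chain carbon, four bonds along the chain from an oxygen on an aromatic ring.

Among the measured compounds shown here, no measured step changes diethylamino itself, so the evidence is indirect. Lengthening a chain gave only a 1.3-fold higher number from compound 1 to compound 2 (0.12 log units; within the scatter) and did not move the number beyond the scatter. The largest step seen is a 2.1-fold lower number from compound 2 to compound 3 (0.33 log units; beyond the scatter) and even that is modest. On these steps, no shift beyond the scatter is expected in this assay for the dibutylamino compound, with a slight rise as the marginally likelier direction. The expected step is a 1.1-fold higher number from compound 3 to compound 4 (0.04 log units; within the scatter) and it remains an estimate on thin evidence. Compound 4 is estimated at 15000 nM with an expected range of 6000 nM to 35000 nM for now.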

Compound 4, half-maximal inhibitory concentration: 5300 nM
For compound 4 the middle estimate is 2.8-fold (0.45 log units) above the measured one; measured number outside the range, below it.
By their numbers in this assay, from the lowest: compound 4; then compounds 3, 1 and 2 (each within the scatter of the next, the first and the last beyond it).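

At this position, on a saturated chain carbon four bonds along the chain from an oxygen on an aromatic ring, the alkyl groups on the amine do matter in this assay: dibutylamino in place of diethylamino gives a 2.6-fold lower number from compound 3 to compound 4 (0.41 log units; beyond the scatter), a modest step but one beyond the scatter. Against the plain alkyl chains the separation is wider, with a 4.2-fold lower number from compound 1 to compound 4 (0.62 log units; beyond the scatter) and a 5.5-fold lower number from compound 2 to compound 4 (0.74 log units; beyond the scatter), which makes compound 4 the strongest of the four shown, whereas compound 3 stood clear of compound 2 alone. No measurement on hand accounts for this shift.

Going by these compounds, two amines are too few to call a trend, so it remains open whether a dihexylamino group or a ring amine such as piperidine would continue or reverse this step. Also open, on these data alone, are how the same amine behaves as 3-(dibutylamino)propyl, and whether a plain alkyl chain much longer than those in compound 1 and compound 2 would match it without any nitrogen.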